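Removing the methoxy from the anilide ring

The compounds below may be only part of what the source reports. "The series", "measured", "known", "first", "only" and "open" are said of these compounds alone.

compound 1 `COc1ccc(NC(=O)C2(C(=O)Nc3ccc(Nc4ncc5cc(C(=O)N(C)C)n(C6CCCC6)c5n4)cc3)CC2)cc1` gives 96.1%
compound 2 `COc1cccc(NC(=O)C2(C(=O)Nc3ccc(Nc4ncc5cc(C(=O)N(C)C)n(C6CCCC6)c5n4)cc3)CC2)c1` gives 93.5%

Within the data shown here, both values come from a functional assay on T47D cells (Homo sapiens) for inhibition, read by CCK-8 assay, with a stated time of 72 h, tested at 10 uM (a lower number here means less inhibition of growth, a higher number more inhibition of growth at the concentration tested), and compound 2 lies within the scatter of compound 1, the only other measured compound. Compound 3 `CN(C)C(=O)c1cc2cnc(Nc3ccc(NC(=O)C4(C(=O)Nc5ccccc5)CC4)cc3)nc2n1C1CCCC1` differs from compound 2 by hydrogen in place of methoxy on an aromatic carbon with hydrogen in place of methoxy on an aromatic carbon, meta to a large group. Among the measured compounds shown here, one measured step bears on this, the change to 3-methoxyphenyl from 4-methoxyphenyl. That step a number 2.6 percentage points lower from compound 1 to compound 2 (within the scatter) is small and stays within the scatter. It keeps the methoxy, however, so the series holds no measurement of losing the group altogether. The expectation is therefore no step beyond the scatter, with only a slight downward lean allowed for that gap in the data. The estimated change is a number 3.5 percentage points lower from compound 2 to compound 3 (within the scatter) in this assay and it remains an expectation until tested. For compound 3 the estimated value is 90% with an expected range of 74% to 99% in this read-out.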

Compound 3, percent growth inhibition at one concentration: 93.9%
Compound 3: the middle estimate sits 3.9 percentage points below what was measured; the measured number falls inside the stated range.
By their numbers in this assay, from the lowest: compounds 2, 3 and 1 (each within the scatter of the next).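

In this assay, among these compounds, the change from 3-methoxyphenyl to phenyl gives the first direct reading of losing the group altogether, and it comes out as a number 0.4 percentage points higher from compound 2 to compound 3 (within the scatter) at this place on the ring. Read against the 4-methoxyphenyl compound, the same loss comes out as a number 2.2 percentage points lower from compound 1 to compound 3 (within the scatter) and so neither methoxy placement separates from the plain phenyl. In these three compounds the methoxy can therefore go without a step beyond the scatter in this read-out, but nothing measured here explains that outcome.

Still open, as far as these compounds go, is whether this tolerance extends to groups of another kind on the same ring, such as a carboxylic acid, a dimethylamino group or a longer chain like butoxy. All three readings also come from one test concentration, so whether compounds that cannot be told apart here would also stay together at lower concentrations remains unanswered.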